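A Methyl Added Where Two Compounds Already Sit Silent

A few compounds are considered here, and "the series" means these few. Any claim that something is new, unique, unknown or untested is made for them only; others in the source may bear on it.

Compound 2 `CC(C)c1ccc(-c2nc(SCc3cn(CC(=O)NC(=O)Nc4ccccn4)nn3)nc(Nc3ccccc3)c2C#N)cc1` was tested in a functional assay on ECa-109 cells (Homo sapiens) for inhibition, read by MTT assay, with a stated time of 72 h; on this read-out higher numbers stand for weaker inhibition and lower numbers for stronger inhibition. In this assay compound 2 gives only a limit, > 64000 nM, and no number. Its close relative compound 1 `CC(C)c1ccc(-c2nc(SCc3cn(CC(=O)NC(=O)Nc4ccccn4)nn3)nc(Nc3ccc(F)cc3)c2C#N)cc1` carries a fluoro on an aromatic carbon instead of a hydrogen. In this assay compound 1 likewise gives only a limit, > 64000 nM. The step that the two limits leave unreadable from compound 1 to compound 2 therefore cannot be read, because of the limit of > 64000 nM in this assay, at which 2 of the 2 values shown sit.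

Compound 3 `Cc1ccc(Nc2nc(SCc3cn(CC(=O)NC(=O)Nc4ccccn4)nn3)nc(-c3ccc(C(C)C)cc3)c2C#N)cc1` is the next step: methyl in place of hydrogen on an aromatic carbon, para to a large group. Among the compounds with values here, no measured step has a readable size, so there is no basis for expecting a direction, and the only evidence, (the limit of > 64000 nM in this assay, at which 2 of the 2 values shown sit), places both measured values at the same limit. Compound 3 is therefore expected to sit at that limit too, and the expected step that the limit leaves unreadable from compound 2 to compound 3 is estimated to be none beyond the scatter. For compound 3 the estimated value is 100000 nM, with a range from 30000 nM to 400000 nM.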

Compound 3, half-maximal inhibitory concentration: 6700 nM
Compound 3: the middle estimate sits 15-fold (1.17 log units) above what was measured; measured number below the stated range.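

Methyl in place of hydrogen on this aromatic carbon gives an at least 9.5-fold lower number from compound 2 to compound 3 (0.98 log units; beyond the scatter) in this assay, the first readable step in this series and evidence that this position can change the read-out. Methyl in place of fluoro at the same carbon gives an at least 9.5-fold lower number from compound 1 to compound 3 (0.98 log units; beyond the scatter), so of the three groups shown here, only methyl yields a number rather than a limit. The step between the other two still cannot be read, because both compounds sit at a limit of the assay and not at a number: the limit of > 64000 nM in this assay, at which 2 of the 3 values shown sit.

The compounds shown leave open whether a longer chain such as ethyl, or a methoxy group, at this same carbon would give a number, and how it would compare with that of compound 3. They also do not show why adding a single carbon here has an effect of this size.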